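Swapping one methoxyphenyl ring in a silyl-protected cyclopentenone

The source may report more compounds than this note shows. Statements on the series, on what has been measured and on what is new or still open speak of the compounds shown alone.

Compound 1, `COc1ccc(C2=C(c3cc(OC)c(OC)c(OC)c3)C(=O)CC2O[SiH2]C(C)(C)C)cc1OC`, is tested in an ADME assay on HT-29 cells (Homo sapiens) for cytotoxicity, read by MTT assay, with a stated time of 72 h; a higher number here means a weaker inhibitor, a lower number a stronger inhibitor. For compound 1 the result is only the limit > 100 ug/mL, which is where two of the three measured values sit (the limit of > 100 ug/mL in this assay, at which 2 of the 3 values shown sit). Compound 2, `COc1ccc(C2=C(c3cc(OC)c(OC)c(OC)c3)CC(O)C2=O)cc1N`, sits at the other limit, < 1 ug/mL, a limit rather than a number (the limit of < 1 ug/mL in this assay, at which 1 of the 3 values shown sits). Compound 3, `COc1ccc(C2=C(c3cc(OC)c(OC)c(OC)c3)C(=O)C(OC(C)=O)C2)cc1OC(C)C`, also reaches only the limit > 100 ug/mL. Within the data shown here, no step between measured compounds differs in a single place, so no measured step size is known. Compound 4, `COc1cc(C2=C(c3cc(C)c(OC)c(C)c3)C(O[SiH2]C(C)(C)C)CC2=O)cc(OC)c1OC`, differs from compound 1 by 4-methoxy-3,5-dimethylphenyl in place of 3,4-dimethoxyphenyl on a double-bonded ring carbon. With compound 1 at a limit, no step beyond the scatter is expected. Compound 4 is estimated at 80 ug/mL, within 20 ug/mL to 200 ug/mL, a step of an at least 1.2-fold lower number from compound 1 to compound 4 (0.09 log units; that floor lies within the scatter).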

Compound 4, half-maximal inhibitory concentration: 10 ug/mL
Estimate against measurement, compound 4: 8.0-fold (0.90 log units) above; measured number outside the range, below it.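

In this assay, 4-methoxy-3,5-dimethylphenyl in place of 3,4-dimethoxyphenyl on a double-bonded ring carbon gives an at least 10-fold lower number from compound 1 to compound 4 (1.00 log units; beyond the scatter), so the ring at this position can change the result. It is the only change at a single place among the compounds shown. The true step may be larger, because compound 1 sits at a limit rather than a number: the limit of > 100 ug/mL in this assay, at which 2 of the 4 values shown sit.

The compounds shown leave open whether the difference follows the two methyl groups or the missing methoxy group. Also open, from the compounds shown here alone, is how a ring carrying a carboxylic acid would behave here.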